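This account rests on a few compounds, and the source may have more. Where it says the series, first, only, none or still open, it means among the compounds named here.

Measured so far:
compound 1 `CSc1ccc(C)cc1NCC1=NCCN1` — 81%
compound 2 `Cc1ccc(S(C)(=O)=O)c(NCC2=NCCN2)c1` — 76%
compound 3 `CS(=O)(=O)c1ccc(Cl)cc1NCC1=NCCN1` — 81%

In a functional assay on CHO cells for agonist activity at Alpha-2C adrenergic receptor (Homo sapiens) (on this read-out lower numbers stand for smaller maximal responses and higher numbers for larger maximal responses), compound 1 gives 81% and stands level with compound 3 at 81%, the two highest readings of the three. Compound 2 gives 76%, within the scatter of compound 1. Compound 4 `CSc1ccc(C(F)(F)F)cc1NCC1=NCCN1` differs from compound 1 by trifluoromethyl in place of methyl on an aromatic carbon. Going by the values given here, no measured step changes this group at this place. The two steps that exist, a number 5 percentage points lower from compound 1 to compound 2 (within the scatter) and a number 5 percentage points higher from compound 2 to compound 3 (within the scatter), both exchanged one ring substituent for another and both stayed within the scatter, so the maximal response in this series has so far been insensitive to such exchanges. On that basis the step of no change at the digits printed from compound 1 to compound 4 (within the scatter) is expected to stay within the scatter. Compound 4 is therefore estimated at 81%, with a range from 71% to 91%.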

Compound 4, largest response reached (reported as maximum), in percent of the reference or control that the assay uses: 45%
Compound 4: middle estimate off by 36 percentage points, on the high side; the whole stated range lies above it.
By their numbers in this assay, from the lowest: compound 4; then compounds 2, 1 and 3 (each within the scatter of the next).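

In this assay, going by these compounds alone, trifluoromethyl in place of methyl gives a number 36 percentage points lower from compound 1 to compound 4 (beyond the scatter), the first step that lies beyond the scatter. The maximal response therefore does depend on the group at this position, on an aromatic carbon para to a methylsulfanyl group. The earlier exchanges gave no sign of this, and chloro in place of methyl at the matching carbon, with methylsulfonyl as the partner group, stayed within the scatter.

Nothing available bears on the cause of this step.

Open, going by these compounds, is whether the loss is confined to trifluoromethyl or extends to methoxy, nitrile or ethyl at this position, and whether it persists with methylsulfonyl in place of methylsulfanyl.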